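A Second Fluoro Group on Compound 3

This account rests on a few compounds, and the source may have more. Where it says the series, first, only, none or still open, it means among the compounds named here.

In an ADME assay on Vero cells (Chlorocebus sabaeus) for cytotoxicity, read by MTT assay, with a stated time of 72 h (a lower number here means that less compound is needed, a higher number that more compound is needed for the effect), compound 3 `O=C(Nc1nc(-c2ccccn2)cs1)c1cccc(F)c1` gives 1200 nM. Compound 1 `CC(=O)c1cccc(C(=O)Nc2nc(-c3ccccn3)cs2)c1` gives 1500 nM, and the step of a 1.3-fold lower number from compound 1 to compound 3 (0.10 log units; within the scatter) puts fluoro in place of acetyl on an aromatic carbon. Compound 2 `O=C(Nc1nc(-c2ccccn2)cs1)c1ccc(Br)cc1` gives 4700 nM, and the step of a 3.9-fold lower number from compound 2 to compound 3 (0.59 log units; beyond the scatter) is modest, with 3-fluorophenyl in place of 4-bromophenyl.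

Compound 4 `O=C(Nc1nc(-c2ccccn2)cs1)c1cc(F)cc(F)c1` differs from compound 3 in one place: fluoro in place of hydrogen on an aromatic carbon, with fluoro in place of hydrogen on an aromatic carbon, meta to a fluoro group and meta to a large group. Among the compounds with values here, none of the measured compounds shows this exact change. The nearest evidence is the step of a 1.3-fold lower number from compound 1 to compound 3 (0.10 log units; within the scatter), which also places a fluoro on an aromatic carbon. The larger step of a 3.9-fold lower number from compound 2 to compound 3 (0.59 log units; beyond the scatter) shows that changes on this aromatic ring can sometimes matter, so the range is kept wide. No shift beyond the scatter is therefore expected, and no direction is favoured with confidence. The expected step is a 1.1-fold higher number from compound 3 to compound 4 (0.03 log units; within the scatter). Compound 4 is estimated at 1300 nM, with an expected range of 600 nM to 3000 nM.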

Compound 4, half-maximal effective concentration: 1500 nM
Beside the measured number, compound 4's estimate is 1.2-fold (0.06 log units) below it; the range from low to high includes it.
By their numbers in this assay, from the lowest: compounds 3, 1 and 4 (each within the scatter of the next); then compound 2.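

In this assay, a fluoro group placed on the aromatic ring of compound 3, meta to a fluoro group and meta to a large group, gives a 1.3-fold higher number from compound 3 to compound 4 (0.10 log units; within the scatter), so at this position the added group brings no shift that can be told from the scatter. Among the steps shown, this is the only one that adds a group to the ring and keeps the fluoro already there; the earlier steps put one group in place of another. Nothing measured here gives a reason for this result.

The compounds shown leave open whether a larger group at this same position, such as methoxy or trifluoromethyl, would also stay within the scatter of compound 3. They also leave open what an amine or a carboxylic acid would do there.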